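Chlorinated amide series: methylsulfonyl replacing chloro, antiproliferative assay

The source may hold more compounds than are shown below. What is called first, only, known or untested is meant among the compounds shown, and "the series" means these compounds.

Measured compounds:
- compound 1, `O=C(Nc1ccc(Cl)c(-c2nnc3c(Cl)cccn23)c1)c1ccc(F)cc1Cl`: > 100000 nM
- compound 2, `O=C(Nc1ccc(Cl)c(-c2nnc3c(Cl)cccn23)c1)c1ccc(Cl)cc1Cl`: > 100000 nM

In a functional assay on U-251 cells (Homo sapiens) for antiproliferative activity, read by MTT assay, with a stated time of 72 h (a higher number here means a weaker inhibitor, a lower number a stronger inhibitor), compound 1 reaches only the limit of the assay, given as > 100000 nM. In this assay compound 2 likewise reaches only the limit, > 100000 nM. The step that the two limits leave unreadable from compound 1 to compound 2 cannot be read, and this is due to the limit of > 100000 nM in this assay, at which 2 of the 2 values shown sit. So compound 2 stands at the ceiling of this assay with no numerical value, and nothing among the measured compounds places it relative to compound 1.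

The change to compound 3, `CS(=O)(=O)c1ccc(C(=O)Nc2ccc(Cl)c(-c3nnc4c(Cl)cccn34)c2)c(Cl)c1`, is methylsulfonyl in place of chloro on an aromatic carbon. No measured step in this series bears on the methylsulfonyl group or on any exchange of a chloro for a different substituent at that position, and the single step shown is itself unreadable. The expectation for compound 3 can therefore rest only on the fact that both measured compounds sit at the limit. It is estimated that compound 3 also gives no measurable inhibition, with the step of a number no higher from compound 2 to compound 3 (the limit leaves the size open) expected to be none beyond the scatter. The estimate for compound 3 is 100000 nM, in a range from 20000 nM to 500000 nM.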

Compound 3, half-maximal inhibitory concentration: 44600 nM
The estimate for compound 3 lay 2.2-fold (0.35 log units) above the measured number, within the range that was stated.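

In this assay, methylsulfonyl in place of chloro on an aromatic carbon gives an at least 2.2-fold lower number from compound 2 to compound 3 (0.35 log units; beyond the scatter), and methylsulfonyl in place of fluoro gives an at least 2.2-fold lower number from compound 1 to compound 3 (0.35 log units; beyond the scatter). Compound 3, at 44600 nM, is the only compound shown with a numerical value, so this position, para to a large group and meta to a chloro group, is one where a substituent exchange can give a numerical read-out. The full size of both steps stays open, and the step between the two halogen compounds cannot be read, due to a single limit: the limit of > 100000 nM in this assay, at which 2 of the 3 values shown sit.

The compounds shown leave open whether the lower number is particular to methylsulfonyl or would also appear with an amine, a carboxylic acid or a nitrile at the same place. They also leave open whether the chloro group meta to this position, which all three compounds share, plays any part in the lower number of compound 3.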